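The source may hold more compounds than are shown below. What is called first, only, known or untested is meant among the compounds shown, and "the series" means these compounds.

Working notes on the series. All four compounds share the core of compound 1 `COc1ccc(-c2ccn(CCC(C)C)c(=O)c2C#N)cc1Cl`. In a functional assay on CHO cells for positive allosteric modulation of metabotropic glutamate receptor 2 (Homo sapiens), read by scintillation counting and GTPgammaS binding, with a stated time of 30 min (a lower number here means a smaller maximal response, a higher number a larger maximal response), compound 1 gives 200%. Compound 2 `CC(C)CCn1ccc(-c2ccc(OC3CCCC3)c(Cl)c2)c(C#N)c1=O` gives 199% in this assay; the step of a number 1 percentage points lower from compound 1 to compound 2 (within the scatter) shows that enlarging the group on the oxygen leaves the maximal response where it was. Compound 3 `CC(C)CCn1ccc(-c2ccc(Oc3ccccc3)cc2)c(C#N)c1=O` gives 188% in this assay, the smallest maximal response of the three measured compounds, beyond the scatter below both compound 2 and compound 1.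

Compound 4 `CNc1ccc(-c2ccn(CCC(C)C)c(=O)c2C#N)cc1` is not yet measured. Its change from compound 3: methylamino in place of phenoxy on an aromatic carbon. For the measured compounds named here, no measured step covers an exchange of an oxygen-linked group for a nitrogen-linked one. Going by the values given here, the only step at this position, a number 1 percentage points lower from compound 1 to compound 2 (within the scatter), concerns the group on the oxygen and was within the scatter; the values of compound 1 and compound 3 show a higher maximal response for the methyl on an oxygen than for phenoxy, though those two compounds also differ elsewhere. On this thin basis a modest rise toward the level of compound 1 is expected for compound 4, as the step of a number 4 percentage points higher from compound 3 to compound 4 (within the scatter). The estimate for compound 4 in this assay is 192%, with a range from 160% to 218%.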

Compound 4, largest response reached (Emax), in percent of the reference or control that the assay uses: 186%
Compound 4: middle estimate off by 6 percentage points, on the high side; the range from low to high includes it.
By their numbers in this assay, from the lowest: compounds 4 and 3 (each within the scatter of the next); then compounds 2 and 1 (each within the scatter of the next).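

In this assay, for the compounds shown here, the exchange at this position gives a number 2 percentage points lower from compound 3 to compound 4 (within the scatter), so the first measured exchange of an oxygen-linked group for a nitrogen-linked one does not separate the two compounds by maximal response. The change is a large one in what is counted: phenoxy, with 7 heavy atoms and a six-membered aromatic ring, gives way to methylamino, with 2 heavy atoms, no ring and 1 hydrogen-bond donor, on an aromatic carbon para to a large group, so for this pair neither the phenoxy ring nor the absence of a donor is required to hold the maximal response at this level. No measurement at hand bears on why the two compounds fall within the scatter of each other.

The compounds shown leave open whether an unsubstituted amino group, a dimethylamino group or a carboxylic acid on this aromatic carbon would keep the maximal response at the same level. Going by these compounds, it also remains open whether the exchange of phenoxy for methylamino would read the same with the chlorine carried by compound 1 and compound 2 on the aromatic ring.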